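Shrinking the oxazole substituent: an aryl amide becomes a methylamide

The source may hold more compounds than are shown below. What is called first, only, known or untested is meant among the compounds shown, and "the series" means these compounds.

Compound 1 `Nc1cccc(-c2cnc(C(=O)CCCCCCc3ccccc3)o2)c1`: 19 nM
Compound 2 `NC(=O)c1ccc(-c2cnc(C(=O)CCCCCCc3ccccc3)o2)cc1`: 10 nM

In an assay (Rattus norvegicus) for inhibition of Fatty-acid amide hydrolase 1 (Homo sapiens) (on this read-out lower numbers stand for stronger inhibition and higher numbers for weaker inhibition), compound 2 gives the lowest of the two numbers, with compound 1 close by at a 1.9-fold lower number from compound 1 to compound 2 (0.28 log units; within the scatter). Compound 3 `CNC(=O)c1cnc(C(=O)CCCCCCc2ccccc2)o1` carries methylcarbamoyl in place of 4-carbamoylphenyl on an aromatic carbon. Going by the values given here, the only measured step at that aromatic carbon, from compound 1 to compound 2, swapped one aryl group for another and stayed within the scatter; no measured step removes the aromatic ring itself. For compound 3 a weaker result is expected, a step of a 12-fold higher number from compound 2 to compound 3 (1.08 log units; beyond the scatter), and its inhibition constant is estimated at 120 nM, with a likely range from 25 nM to 600 nM.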

Compound 3, inhibition constant: 7 nM
For compound 3 the middle estimate is 17-fold (1.23 log units) above the measured one; the whole stated range lies above it.
By their numbers in this assay, from the lowest: compounds 3, 2 and 1 (each within the scatter of the next, the first and the last beyond it).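

Taking away the six-membered aromatic ring at this carbon and leaving 4 heavy atoms in place of 9 does not move the read-out in this assay (a 1.4-fold lower number from compound 2 to compound 3 (0.15 log units; within the scatter)), so among these compounds the aromatic ring is not needed at this position. The methylamide also stands apart from the 3-aminophenyl group (a 2.7-fold lower number from compound 1 to compound 3 (0.43 log units; beyond the scatter)), a modest step beyond the scatter. Nothing at hand explains either step.

As far as these compounds go, whether a carboxylic acid or a nitrile on this carbon would hold the number remains open. So does how a longer chain on the amide nitrogen would read.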